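A few compounds are considered here, and "the series" means these few. Any claim that something is new, unique, unknown or untested is made for them only; others in the source may bear on it.

Measured compounds:
compound 1, `Cc1ccc(S(=O)(=O)Oc2ccc3c(c2C)[C@H](Cn2cc(-c4ccc(Br)cc4)nn2)[C@@]24CC(=O)[C@@](C)(CC[C@@H]32)C4)cc1` — > 20000 nM
compound 2, `C=C1C[C@]23C[C@@]1(O)CC[C@H]2c1ccc(O)c(C)c1[C@@H]3Cn1cc(-c2ccc(F)cc2)nn1` — > 20000 nM

In a functional assay on SW480 cells (Homo sapiens) for cytotoxicity, read by MTT assay, with a stated time of 4 days (on this read-out lower numbers stand for stronger inhibition and higher numbers for weaker inhibition), compound 1 gives only a limit, > 20000 nM, and no number. Compound 2 gives a limit too in this assay, > 20000 nM. Among the measured compounds shown here, both values sit on (the limit of > 20000 nM in this assay, at which 2 of the 2 values shown sit), so no measured step exists within the set and compound 1 cannot be ordered against compound 2; the two show only that neither reaches a measurable value in the tested range, and nothing more.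

Compound 3, `COc1ccc(-c2cn(C[C@H]3c4c(ccc(OS(=O)(=O)c5ccc(C)cc5)c4C)[C@@H]4CC[C@@]5(C)C[C@]43CC5=O)nn2)cc1`, is not yet measured in this assay. It differs from compound 1 by methoxy in place of bromo on an aromatic carbon; the rest of the structure is unchanged. For the measured compounds named here, no measured step is available to scale the change, and the starting point is itself a limit, which leaves the direction open.

The expected step from compound 1 to compound 3 is a step that the limit leaves unreadable from compound 1 to compound 3, that is none beyond the scatter, because compound 1 stands on (the limit of > 20000 nM in this assay, at which 2 of the 2 values shown sit). Compound 3 is estimated at 25000 nM, with a range from 8000 nM to 60000 nM, and the measurement is expected most likely to come back as a limit again rather than a number.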

Compound 3, half-maximal inhibitory concentration: > 20000 nM
Compound 3: only a limit was reported; the forecaster's own chance of this, stated with the estimate: 75%; the middle value does not contradict the limit.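

In this assay compound 3 gives > 20000 nM as a limit and not a number, so no step from compound 1 to compound 3 can be read: the limit of > 20000 nM in this assay, at which 3 of the 3 values shown sit.

The compounds shown leave open whether methoxy in place of bromo on an aromatic carbon changes the read-out at all, and which structures in this series would give a measured number.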